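The source may hold more compounds than are shown below. What is called first, only, known or untested is meant among the compounds shown, and "the series" means these compounds.

For the measured compounds named here, compound 2 `O=C(Nc1ccc(Oc2ccnc3[nH]ccc23)cc1)c1cc2cccnc2n(-c2ccc(Br)cc2F)c1=O` gives 2360 nM in a functional assay on HT-29 cells (Homo sapiens) for antiproliferative activity, read by MTT assay, with a stated time of 72 h (a higher number here means a weaker inhibitor, a lower number a stronger inhibitor), the higher of the two numbers measured so far. Compound 1 `O=C(Nc1ccc(Oc2ccnc3[nH]ccc23)cc1)c1cc2cccnc2n(-c2ccc(F)c(Cl)c2)c1=O` gives 560 nM in this assay. Going by the values given here, the single measured step, a 4.2-fold higher number from compound 1 to compound 2 (0.62 log units; beyond the scatter), concerns only the aryl group on the aromatic nitrogen. Among the compounds with values here, compound 3 `O=C(Nc1ccc(Oc2ccnc3[nH]ccc23)c(F)c1)c1cc2cccnc2n(-c2ccc(Br)cc2F)c1=O` differs from compound 2 by fluoro in place of hydrogen on an aromatic carbon, a position no measured step touches, so nothing here bears on it. In this assay the expected step of a 1.2-fold lower number from compound 2 to compound 3 (0.07 log units; within the scatter) is accordingly none beyond the scatter. Compound 3 is estimated at 2000 nM, with a range from 700 nM to 6000 nM.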

Compound 3, half-maximal inhibitory concentration: 820 nM
For compound 3 the middle estimate is 2.4-fold (0.39 log units) above the measured one; measured number inside the range.
By their numbers in this assay, from the lowest: compounds 1 and 3 (each within the scatter of the next); then compound 2.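

In this assay, fluoro in place of hydrogen on an aromatic carbon gives a 2.9-fold lower number from compound 2 to compound 3 (0.46 log units; beyond the scatter), so this position, ortho to a large group and meta to a large group, is not silent to substitution. For the compounds shown here, until now, the only measured change lay in the aryl group on the aromatic nitrogen. Nothing available explains this step.

Open, from the compounds shown here alone, is whether chloro, methyl or an amine at this position would give a similar step. Also open, going by these compounds, is whether fluoro gives the same step alongside the 3-chloro-4-fluorophenyl group of compound 1.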